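The compounds below may be only part of what the source reports. "The series", "measured", "known", "first", "only" and "open" are said of these compounds alone.

Working notes on the series. Compound 1 `NC(=O)C[C@H](NC(=O)CN(c1ncnc2c1ncn2C1CCCCO1)C1CC1)C(=O)OCc1ccccc1` in a functional assay on the whole organism (Tail, strain ICR) with Mus musculus as the target, in the tail flick test, with a stated time of 90 min, at a dose of 25 umol/kg by the oral route (a higher number here means a stronger effect of the compound at the dose given, a lower number a weaker effect), gives 35%. Compound 2 `O=C(CN(c1ncnc2c1ncn2C1CCCCO1)C1CC1)N[C@@H](CC(=O)OCc1ccccc1)C(=O)OCc1ccccc1` in this assay gives 25.1%, so compound 2 and compound 1 sit inside the usual scatter of each other, the step of a number 9.9 percentage points lower from compound 1 to compound 2 (within the scatter). Compound 3 `C[C@H](NC(=O)CN(c1ncnc2c1ncn2C1CCCCO1)C1CC1)C(=O)OCc1ccccc1` is unmeasured; it differs from compound 2 by hydrogen in place of benzyloxycarbonyl on a saturated chain carbon, two bonds along the chain from an amide-type nitrogen and a carbonyl carbon. Within the data shown here, the only measured step alters the same side chain end and stayed within the scatter, so no change beyond the scatter is expected in this assay for compound 3, an estimated step of a number 2.9 percentage points higher from compound 2 to compound 3 (within the scatter). Compound 3 is therefore estimated at 28%, expected between 10% and 46%.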

Compound 3, a percentage reported as activity, at one dose (the size of the read-out at that dose, not a potency): 32.1%
Compound 3: the middle estimate sits 4.1 percentage points below what was measured; the range from low to high includes it.
By their numbers in this assay, from the lowest: compounds 2, 3 and 1 (each within the scatter of the next).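

Hydrogen in place of benzyloxycarbonyl on this saturated chain carbon, which leaves a methyl at that position, takes away the whole group and still stays inside the scatter in this assay (a number 7 percentage points higher from compound 2 to compound 3 (within the scatter)). Hydrogen in place of carbamoyl at the same carbon also stays inside it (a number 2.9 percentage points lower from compound 1 to compound 3 (within the scatter)), so neither group is shown to matter for the read-out at this dose. Nothing available here bears on why these three compounds read alike.

Still open, from the compounds shown here alone, is whether a carboxylic acid or an amine on this carbon, or a longer chain there, would give a step beyond the scatter. A read-out at one dose also leaves the size of the effect at other doses open.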